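A Methyl Ortho to the Nitro Group

The source may hold more compounds than are shown below. What is called first, only, known or untested is meant among the compounds shown, and "the series" means these compounds.

Compound 2 `COc1ccc(-c2cc(=O)c3c(OC)cc(OC)cc3n2S(=O)(=O)c2cccc([N+](=O)[O-])c2)cc1` carries a 3-nitrophenyl on its sulfonyl sulfur. In a functional assay on SUP-B15 cells (Homo sapiens) for antiproliferative activity, with a stated time of 72 h (on this read-out higher numbers stand for an effect only at larger amounts of compound and lower numbers for an effect already at smaller amounts), compound 2 reaches only a limit of the assay, > 39600 nM, and no number. Its companion compound 1 `COc1ccc(-c2cc(=O)c3c(OC)cc(OC)cc3n2S(=O)(=O)c2ccc([N+](=O)[O-])cc2)cc1` differs by a 4-nitrophenyl on the same sulfur, and in this assay compound 1 gives 17100 nM. Within the data shown here, the single measured step, an at least 2.3-fold higher number from compound 1 to compound 2 (0.36 log units; beyond the scatter), thus runs toward weaker activity and ends at the limit of > 39600 nM in this assay, at which 1 of the 2 values shown sits. Compound 3 `COc1ccc(-c2cc(=O)c3c(OC)cc(OC)cc3n2S(=O)(=O)c2ccc(C)c([N+](=O)[O-])c2)cc1` is built from compound 2 by one change: methyl in place of hydrogen on an aromatic carbon. Among the measured compounds shown here, no measured step in this set concerns a methyl, so the expectation rests on where compound 2 sits, namely at the limit with no measured move away from it. The step that the limit leaves unreadable from compound 2 to compound 3 is therefore expected to stay within the scatter. Compound 3 is estimated at 45000 nM, between 15000 nM and 130000 nM, most likely reported once more as a limit.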

Compound 3, half-maximal effective concentration: > 51700 nM
Compound 3: only a limit was reported; the forecaster's own chance of this, stated with the estimate: 65%; middle value at least 1.1-fold (0.06 log units) from the limit.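

In this assay, the 4-methyl-3-nitrophenyl group in place of 4-nitrophenyl on the sulfonyl sulfur gives an at least 3.0-fold higher number from compound 1 to compound 3 (0.48 log units; beyond the scatter), so adding methyl ortho to a nitro group does not recover a readable number. Of the three compounds, only compound 1 gives a number, 17100 nM. The step from compound 2 to compound 3 cannot be read, because compound 3, like compound 2, stops at a limit of the assay: the limit of > 51700 nM in this assay, at which 1 of the 3 values shown sits.

The compounds shown therefore leave open whether the methyl changes anything at all on the 3-nitrophenyl ring, since neither compound gives a number from which a change could be read. They also leave open whether an amine or a carboxylic acid in place of the nitro group would give a readable value in this assay.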